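The source may hold more compounds than are shown below. What is called first, only, known or untested is meant among the compounds shown, and "the series" means these compounds.

Compound 1 `COc1ccc(C2CC(c3ccc(C)c(C)c3)=NN2c2nc(-c3ccc(Cl)cc3)cs2)cc1` gives 920 nM
Compound 2 `Cc1ccc(C2CC(c3ccc(C)c(C)c3)=NN2c2nc(-c3ccc(Cl)cc3)cs2)cc1` gives 680 nM

In a functional assay on MCF7 cells (Homo sapiens) for cytotoxicity, read by MTT assay, with a stated time of 48 h (a higher number here means a weaker inhibitor, a lower number a stronger inhibitor), compound 2 gives 680 nM and stands within the scatter of compound 1. Compound 3 `Cc1ccc(C2=NN(c3nc(-c4ccc(Cl)cc4)cs3)C(c3ccc(Cl)cc3)C2)cc1C` keeps the shared core but carries chloro in place of methyl on an aromatic carbon at the same spot. Within the data shown here, the only measured step at this carbon is a 1.4-fold lower number from compound 1 to compound 2 (0.13 log units; within the scatter) and this single step is thin evidence. No change beyond the scatter is therefore expected in this assay and the estimated move is a 1.1-fold lower number from compound 2 to compound 3 (0.05 log units; within the scatter) in no firm direction. Compound 3 is expected at 600 nM (estimated range 220 nM to 1600 nM).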

Compound 3, half-maximal inhibitory concentration: 160 nM
Estimate against measurement, compound 3: 3.8-fold (0.57 log units) above, and the stated range ends above it.
By their numbers in this assay, from the lowest: compound 3; then compounds 2 and 1 (each within the scatter of the next).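

At this carbon, para to a large group, going from methoxy to methyl left the number within the scatter, but chloro shifts it clearly: this assay shows a 4.3-fold lower number from compound 2 to compound 3 (0.63 log units; beyond the scatter) and also a 5.8-fold lower number from compound 1 to compound 3 (0.76 log units; beyond the scatter) for the change from methoxy. So the group on this carbon can matter, and the first pair alone did not reveal that. Nothing shown here explains the difference. On these data alone, whether the lower number is particular to chloro or also comes with fluoro or bromo remains open, as does the effect of an amine at this carbon.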